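The source may report more compounds than this note shows. Statements on the series, on what has been measured and on what is new or still open speak of the compounds shown alone.

Measured so far in an assay on Cerebral cortex for binding affinity to adenosine receptor A1 (Cavia porcellus), read by radioligand binding; a higher number here means a weaker inhibitor, a lower number a stronger inhibitor:
- compound 1 `C=CCn1c(=O)c2[nH]cnc2n(CCC)c1=O`: 1700 nM
- compound 2 `CCCn1c(=O)n(CCC#N)c(=O)c2[nH]cnc21`: 15900 nM
- compound 3 `CCCn1c(=O)n(CCN(C)C)c(=O)c2[nH]cnc21`: 4300 nM

Compound 3 holds the second highest of the three numbers in this assay; the steps of a 2.5-fold higher number from compound 1 to compound 3 (0.40 log units; beyond the scatter) and a 3.7-fold lower number from compound 2 to compound 3 (0.57 log units; beyond the scatter) place it between the other two, both gaps beyond the scatter. Compound 4 `CCCn1c(=O)n(CCCO)c(=O)c2[nH]cnc21` carries the change (hydroxymethyl in place of dimethylamino on a saturated chain carbon, two bonds along the chain from an aromatic nitrogen). Going by the values given here, no measured step swaps in a hydroxyl; the only steps that bear on it are the other exchanges at this chain position, a 9.4-fold higher number from compound 1 to compound 2 (0.97 log units; beyond the scatter), a 2.5-fold higher number from compound 1 to compound 3 (0.40 log units; beyond the scatter) and a 3.7-fold lower number from compound 2 to compound 3 (0.57 log units; beyond the scatter), all modest in size and in either direction. A modest step is therefore expected, probably towards a higher number, a 1.2-fold lower number from compound 3 to compound 4 (0.09 log units; within the scatter). Compound 4 is estimated at 3500 nM, with a range of 1200 nM to 9000 nM.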

Compound 4, inhibition constant: 12000 nM
For compound 4 the middle estimate is 3.4-fold (0.54 log units) below the measured one; the measured number lies above the stated range.
By their numbers in this assay, from the lowest: compound 1; then compound 3; then compounds 4 and 2 (each within the scatter of the next).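

Among the chain ends tried in this assay the hydroxyl of compound 4 does not share the lower number of the dimethylamino chain (a 2.8-fold higher number from compound 3 to compound 4 (0.45 log units; beyond the scatter)). It falls instead within the scatter of the nitrile chain (a 1.3-fold lower number from compound 2 to compound 4 (0.12 log units; within the scatter)), so these two ends cannot be told apart here. The vinyl-ended chain of compound 1 keeps the lowest number, and the hydroxyl does not recover it (a 7.1-fold higher number from compound 1 to compound 4 (0.85 log units; beyond the scatter)).

From the compounds shown here alone, whether a primary amine, a carboxylic acid or a longer chain at this end would reach compound 1 stays open. Nothing on hand gives a reason for this order.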